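The source may report more compounds than this note shows. Statements on the series, on what has been measured and on what is new or still open speak of the compounds shown alone.

Measured in a functional assay on the whole organism (strain Wister albino) for inhibition, with Rattus norvegicus as the target, read by paw edema, with a stated time of 1 h, at a dose of 50 mg/kg by the intraperitoneal route; on this read-out higher numbers stand for more inhibition at the one dose given (going by the name of the read-out) and lower numbers for less inhibition:

- compound 1, `Cc1ccc([C@@H]2CN(C)[C@]3(C(=O)Nc4ccccc43)[C@]23Cc2ccccc2C3=O)cc1`: 56.4%
- compound 2, `CN1C[C@@H](c2ccccc2)[C@@]2(Cc3ccccc3C2=O)[C@@]12C(=O)Nc1ccccc12`: 56%
- compound 3, `CN1C(=O)[C@@]2(c3ccccc31)N(C)C[C@@H](c1ccco1)[C@@]21Cc2ccccc2C1=O`: 50.1%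

Compound 1 stands at 56.4%. The numbers of compound 2 and compound 3 both lie within the scatter of that value, so the three measured compounds cannot be separated on this read-out. Going by the values given here, the single step between compounds that differ in one place is a number 0.4 percentage points lower from compound 1 to compound 2 (within the scatter), a change within the scatter.

Compound 4, `Cc1ccc([C@@H]2CN(C)[C@]3(C(=O)N(C)c4ccccc43)[C@]23Cc2ccccc2C3=O)cc1`, differs from compound 1 by methyl in place of hydrogen on an amide-type nitrogen in a ring. Among the compounds with values here, no measured pair alters anything at this amide-type nitrogen, so no step bears directly on the change; the one available step concerns an aromatic carbon and stayed within the scatter, and all three measured numbers cluster together. On that basis the step in this assay is expected to be a number 5.4 percentage points lower from compound 1 to compound 4 (within the scatter), not beyond the scatter. Compound 4 is estimated at 51%, with a range from 36% to 63%.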

Compound 4, a percentage reported as inhibition, in the whole organism at one dose (the size of the read-out at that dose, not a potency): 46.9%
Compound 4: middle estimate off by 4.1 percentage points, on the high side; low and high end bracket the measured number.
By their numbers in this assay, from the lowest: compounds 4, 3, 2 and 1 (each within the scatter of the next).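

In this assay, methyl in place of hydrogen on the amide-type nitrogen in a ring gives a number 9.5 percentage points lower from compound 1 to compound 4 (within the scatter) and is the first change shown at this nitrogen, which carries the methyl without a step beyond the scatter. With that methyl present, 4-methylphenyl in place of furan-2-yl on a saturated ring carbon gives a number 3.2 percentage points lower from compound 3 to compound 4 (within the scatter) and so does not separate the two ring groups on this read-out. Nothing at hand bears on the origin of either step.

On these data alone, whether a group other than methyl on this nitrogen, such as benzyl, or a longer chain ending in an amine or a carboxylic acid, moves the number beyond the scatter remains open. As far as these compounds go, the read-out at other doses and times also remains open for this series.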